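Changing the amide substituent of compound 3

The source may hold more compounds than are shown below. What is called first, only, known or untested is meant among the compounds shown, and "the series" means these compounds.

In a physicochemical assay for lipophilicity, at pH 7.4 (on this read-out lower numbers stand for lower lipophilicity and higher numbers for higher lipophilicity), compound 3 `CNC(=O)c1cc(C(=O)N[C@H]2CC[C@H](O)CC2)cc2c1OC[C@@]2(C)c1ccccc1` gives 3.3. Compound 1 `CNC(=O)c1cc(C(=O)N[C@H]2[C@@H]3COC[C@@H]32)cc2c1OC[C@H]2c1cccc2[nH]ccc12`, at 3.1, lies within the scatter of it, while compound 2 `CNC(=O)c1cc(C(=O)N[C@H]2[C@@H]3COC[C@@H]32)cc2c1OC[C@H]2c1ccncc1`, at 1.3, lies well below both. Compound 4 `CNC(=O)c1cc(C(=O)N[C@H]2C[C@@H]2C)cc2c1OC[C@@]2(C)c1ccccc1` carries 2-methylcyclopropyl in place of 4-hydroxycyclohexyl on an amide-type nitrogen. For the measured compounds named here, the only measured step, a number 1.80 log units lower from compound 1 to compound 2 (beyond the scatter), is large, but it concerns a saturated ring carbon, not this nitrogen. Going by the values given here, it shows only that one exchange can shift this assay widely, and no measured pair tests the present exchange. On this thin evidence, a modest rise is expected, a number 0.40 log units higher from compound 3 to compound 4 (beyond the scatter). Compound 4 is estimated at 3.7, with an expected range of 3.2 to 4.2.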

Compound 4, distribution coefficient: 4.7
Beside the measured number, compound 4's estimate is 1.00 log units below it; measured number above the stated range.
By their numbers in this assay, from the lowest: compound 2; then compounds 1 and 3 (each within the scatter of the next); then compound 4.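

For the compounds shown here, on the amide-type nitrogen, the exchange of 4-hydroxycyclohexyl for 2-methylcyclopropyl gives, in this assay, a number 1.40 log units higher from compound 3 to compound 4 (beyond the scatter), the first measured step at this position and a large one. The substituent on this nitrogen therefore matters strongly for this read-out, although the exchange alters the ring, the heavy-atom count and the hydrogen-bond donors and acceptors all at once. Nothing available accounts for the size of this step.

The compounds shown leave open where plain cyclohexyl, or cyclohexyl carrying an amine, would fall in this assay. Which part of the exchange carries the step therefore remains unresolved.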